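Trimming the allyl of compound 1 to methyl

The compounds below may be only part of what the source reports. "The series", "measured", "known", "first", "only" and "open" are said of these compounds alone.

Measured compounds:
- compound 1, `C=CCC1C(=C)C(=O)N(c2ccccc2)N1c1ccccc1`: 1320 nM
- compound 2, `C=C1CN(C)N(c2ccc(Cl)cc2)C1=O`: 38100 nM
- compound 3, `C=C1C(=O)N(c2ccccc2)N(C)C1CCCCCCCCC`: 49900 nM

The three measured compounds were tested in a functional assay on HL-60 cells (Homo sapiens) for inhibition, read by MTT assay, with a stated time of 48 h; a lower number here means a stronger inhibitor, a higher number a weaker inhibitor. Compound 1 stands lowest of the three. Compound 2 sits well beyond the scatter from it, and compound 3 sits further still; compound 2 and compound 3 lie near each other, and neither pair differs from compound 1 in a single place, so their values are reported here only as they stand.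

The unmeasured compound 4, `C=C1C(=O)N(c2ccccc2)N(c2ccccc2)C1C`, keeps the core of compound 1 together with both phenyl groups on nitrogen, and differs from it in one place: hydrogen in place of vinyl on a saturated chain carbon bound to a saturated ring carbon. Cut one bond further out, the same change reads as allyl to methyl.

For the measured compounds named here, with no measured pair that isolates this change, the step is expected to be modest, trending toward a slightly higher number; the estimate for compound 4 amounts to a 1.9-fold higher number from compound 1 to compound 4 (0.28 log units; within the scatter) in this assay. Compound 4 is accordingly expected to give about 2500 nM, within a range of 800 nM to 8000 nM.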

Compound 4, half-maximal inhibitory concentration: 5850 nM
Estimate against measurement, compound 4: 2.3-fold (0.37 log units) below; the range from low to high includes it.
By their numbers in this assay, from the lowest: compound 1; then compound 4; then compounds 2 and 3 (each within the scatter of the next).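

In this assay, hydrogen in place of vinyl on a saturated chain carbon bound to a saturated ring carbon, which cut one bond further out reads as allyl to methyl, gives a 4.4-fold higher number from compound 1 to compound 4 (0.65 log units; beyond the scatter). For the compounds shown here, this is the first comparison here that isolates a single change, and it shows that, with the core of compound 1 and both phenyl groups on nitrogen kept, the number at this place responds beyond the scatter to trimming the allyl group. Nothing at hand offers an explanation for this step.

As far as these compounds go, what a propyl chain would give at this place remains open, and with it whether the double bond or the chain length accounts for the step. Equally open, from the compounds shown here alone, is how a chain ending in an amine or a carboxylic acid would read in this assay.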